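Amide replacing carbamate on the piperidine carbonyl

The compounds below may be only part of what the source reports. "The series", "measured", "known", "first", "only" and "open" are said of these compounds alone.

Within the data shown here, compound 1 `Cc1nc(S(C)(=O)=O)ccc1Oc1ncnc(OC2CCN(C(=O)O[C@@H](C)CF)CC2)c1F` gives 186 nM in a functional assay on isolated protein for inhibition of Glucose-dependent insulinotropic receptor (Homo sapiens), read by HTRF and cAMP accumulation (on this read-out lower numbers stand for an effect already at smaller amounts and higher numbers for an effect only at larger amounts of compound), and stands highest of the two numbers so far; its nearest neighbour, compound 2 `Cc1nc(S(C)(=O)=O)ccc1Oc1ncnc(OC2CCN(C(=O)SC3CCC3)CC2)c1F`, gives 8.51 nM. Among the measured compounds shown here, the one measured step, a 22-fold lower number from compound 1 to compound 2 (1.34 log units; beyond the scatter), shows that what sits on that carbonyl carbon can move the number a long way. Compound 3 `CCc1cnc(C(=O)N2CCC(Oc3ncnc(Oc4ccc(S(C)(=O)=O)nc4C)c3F)CC2)nc1` differs from compound 1 by a group of 8 heavy atoms (6 carbon, 2 nitrogen; one six-membered aromatic ring with 2 hetero atoms) in place of a group of 5 heavy atoms (3 carbon, 1 oxygen, 1 fluorine; no ring), on a carbonyl carbon. That step bears only indirectly on the new group, since no ring of this kind has been measured, but the large gain seen for compound 2 makes a lower number the expected direction. Compound 3 is therefore estimated at 25 nM, within 6 nM to 100 nM, an expected 7.4-fold lower number from compound 1 to compound 3 (0.87 log units; beyond the scatter).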

Compound 3, half-maximal effective concentration: 4.7 nM
The estimate for compound 3 lay 5.3-fold (0.73 log units) above the measured number; the measured number lies below the stated range.
By their numbers in this assay, from the lowest: compounds 3 and 2 (each within the scatter of the next); then compound 1.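

With 5-ethylpyrimidin-2-yl on the carbonyl carbon, an aromatic ring also carries a large step (a 40-fold lower number from compound 1 to compound 3 (1.60 log units; beyond the scatter)), so a step of this size is not confined to cyclobutylsulfanyl. The second step (a 1.8-fold lower number from compound 2 to compound 3 (0.26 log units; within the scatter)) leaves 5-ethylpyrimidin-2-yl and cyclobutylsulfanyl indistinguishable on this read-out. Nothing available explains either step.

Open: whether the ethyl group contributes to the low number, and whether an unsubstituted pyrimidin-2-yl, a phenyl or a dimethylamino group on this carbonyl carbon would keep it.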